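The source may hold more compounds than are shown below. What is called first, only, known or untested is meant among the compounds shown, and "the series" means these compounds.

Compound 1 `CCCCCCCCCC(O)C#CC#CC(O)C1CCCCC1` was tested in a toxicity assay on Hepa-1c1c7 cells (Mus musculus) for inhibition (a higher number here means a weaker inhibitor, a lower number a stronger inhibitor), and gave 44000 nM. Compound 2 `CCCCCCCCCC(O)C#CC#CC(O)CC(C)C` reached only the limit of this assay, reported as > 50000 nM. The change from the one to the other is isobutyl in place of cyclohexyl on a saturated chain carbon bound to an oxygen on a saturated carbon and a triple-bonded carbon, and it produced an at least 1.1-fold higher number from compound 1 to compound 2 (0.05 log units; that floor lies within the scatter). Compound 3 `OC(C#CC#CC(O)C1CCCCC1)C1CCCCC1` likewise came out at the limit of this assay, reported as > 50000 nM. How the core of compound 3 differs from that of compound 1 is not broken down here. Compound 4 `CC(C)CC(O)C#CC#CC(O)C1CCCCC1` has not yet been measured; it carries the same change, (isobutyl in place of cyclohexyl on a saturated chain carbon bound to an oxygen on a saturated carbon and a triple-bonded carbon). Because the limit of > 50000 nM in this assay, at which 2 of the 3 values shown sit, is where compound 3 already sits, compound 4 is expected to show a step that the limit leaves unreadable from compound 3 to compound 4, a step no larger than the earlier one. Compound 4 is therefore estimated at 80000 nM, between 30000 nM and 300000 nM, most likely once more only a limit.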

Compound 4, half-maximal inhibitory concentration: > 50000 nM
Compound 4 gave a limit, no number (the forecaster's own chance of this, stated with the estimate: 85%); the middle value does not contradict the limit.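

For the compounds shown here, compound 3 and compound 4 both stand at a limit in this assay, so no step between them can be read: the limit of > 50000 nM in this assay, at which 3 of the 4 values shown sit. The compounds shown leave open whether isobutyl in place of cyclohexyl changes the number at all in compound 3.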